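A few compounds are considered here, and "the series" means these few. Any claim that something is new, unique, unknown or untested is made for them only; others in the source may bear on it.

In a functional assay on A-375 cells (Homo sapiens) for antiproliferative activity, read by CCK-8 assay, with a stated time of 72 h, tested at 2 uM (a lower number here means a weaker effect, a higher number a stronger effect of the compound at the concentration tested), compound 1 `Nc1ccccc1NC(=O)c1ccc(CSC(=S)N2CCN(C3CCCCC3)CC2)cc1` gives 31.7%, the higher of the two numbers on hand, though compound 2 `Nc1ccccc1NC(=O)c1ccc(CSC(=S)N2CCCc3ccccc32)cc1` gives 26.5%, a value within the scatter of that of compound 1. Compound 3 `Nc1ccccc1NC(=O)c1ccc(CSC(=S)N2CCN(Cc3cccnc3)CC2)cc1` has not yet been tested there; it differs from compound 1 by (pyridin-3-yl)methyl in place of cyclohexyl on an amine nitrogen in a ring. For the measured compounds named here, no measured pair shows this change, so its size is unknown. The account expects no step beyond the scatter in either direction, with the change from compound 1 to compound 3 estimated at a number 1.7 percentage points lower from compound 1 to compound 3 (within the scatter). Compound 3 is therefore expected to give 30%, with a range from 15% to 45%.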

Compound 3, a percentage reported as inhibition, at one concentration (the size of the read-out at that concentration, not a potency): 31.5%
Compound 3: middle estimate off by 1.5 percentage points, on the low side; the measured number falls inside the stated range.
By their numbers in this assay, from the lowest: compounds 2, 3 and 1 (each within the scatter of the next).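

In this assay the read-out stands a number 0.2 percentage points lower from compound 1 to compound 3 (within the scatter) when (pyridin-3-yl)methyl takes the place of cyclohexyl on this amine nitrogen in a ring. This first measured change at the position shows that a non-aromatic carbon ring can give way to an aromatic ring with one hetero atom without a step beyond the scatter. Nothing on hand explains this result.

Going by these compounds, whether benzyl, a primary amine, a carboxylic acid or a longer chain at this position would give a step beyond the scatter remains open. With one concentration, these numbers also leave potency open.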